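Chloro in place of methoxy: working notes on the series

This account rests on a few compounds, and the source may have more. Where it says the series, first, only, none or still open, it means among the compounds named here.

Values in a functional assay on MCF7 cells (Homo sapiens) for cytotoxicity, read by MTT assay, with a stated time of 48 h; on this read-out lower numbers stand for stronger inhibition and higher numbers for weaker inhibition:
- compound 1 `CC1(C)CCCC2=CC=C(C=O)CC[C@]21C`: 167000 nM
- compound 2 `C=C1CCC[C@]2(C)CCC(c3cn(-c4ccc(OC)cc4)nn3)=CC[C@@]12C`: 118000 nM

Not yet measured: compound 3 `C=C1CCC[C@]2(C)CCC(c3cn(-c4ccc(Cl)cc4)nn3)=CC[C@@]12C`.

Going by the values given here, only two numbers are available so far. Compound 1 gives 167000 nM and compound 2 gives 118000 nM. These two values lie within the usual scatter of each other, so compound 2 cannot be ranked against compound 1. Among the compounds with values here, the two compounds also differ in more than one place, and no measured pair isolates a single change.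

Compound 3 keeps the core of compound 2 and carries chloro in place of methoxy on an aromatic carbon, para to a large group, which turns 4-methoxyphenyl into 4-chlorophenyl: chloro in place of methoxy on an aromatic carbon. Within the data shown here, the data hold no direct precedent for this exchange. In this assay no step beyond the scatter is expected, with at most a slight lean towards a lower number, and the anchor is compound 2 at 118000 nM. The expected step is a 1.2-fold lower number from compound 2 to compound 3 (0.07 log units; within the scatter). The estimate for compound 3 is 100000 nM, with an expected range from 45000 nM to 220000 nM.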

Compound 3, half-maximal inhibitory concentration: 35100 nM
Compound 3: middle estimate off by 2.8-fold (0.45 log units), on the high side; the measured number lies below the stated range.
By their numbers in this assay, from the lowest: compound 3; then compounds 2 and 1 (each within the scatter of the next).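

In this assay the series now has its first comparison that isolates a single change: going from 4-methoxyphenyl to 4-chlorophenyl gives a 3.4-fold lower number from compound 2 to compound 3 (0.53 log units; beyond the scatter), a step beyond the scatter. This shows that the group on this aromatic carbon, para to a large group, matters to the read-out with the rest of compound 2 held constant, something the earlier pair could not show, as its members differ in more than one place. No measurement at hand bears on why chloro gives the lower number, so the step stands as an observation only.

This single exchange leaves open whether the step is particular to chloro or whether methoxy is simply a poor group here, and a plain hydrogen, fluoro, methyl, trifluoromethyl or an amine on the same carbon would help separate those readings. Also open, from the compounds shown here alone, is whether the step carries over to other cell lines, since compound 3 at 35100 nM is known from this one cytotoxicity read-out alone.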